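Working notes: ((tert-butyl)carbonyl)oxy in place of chloro

The source may hold more compounds than are shown below. What is called first, only, known or untested is meant among the compounds shown, and "the series" means these compounds.

Within the data shown here, compound 2 `C[S+]([O-])/C=C/c1cc(=O)c2cc(Cl)ccc2o1` gives 1700 nM in a functional assay on A549 cells (Homo sapiens) for cytotoxicity, with a stated time of 48 h (on this read-out higher numbers stand for weaker inhibition and lower numbers for stronger inhibition), and stands highest of the two numbers so far, with compound 1 `CCOc1ccc2oc(/C=C/[S+](C)[O-])cc(=O)c2c1` nearest at 1500 nM. Among the measured compounds shown here, the one measured step, a 1.1-fold higher number from compound 1 to compound 2 (0.05 log units; within the scatter), put chloro in place of ethoxy and stayed within the scatter. Compound 3 `C[S+]([O-])/C=C/c1cc(=O)c2cc(OC(=O)C(C)(C)C)ccc2o1` carries ((tert-butyl)carbonyl)oxy in place of chloro on an aromatic carbon. For the measured compounds named here, no measured step bears directly on this group; the only guide is that ethoxy and chloro gave comparable numbers, so a shift beyond the scatter is not expected. The step expected is a 1.1-fold higher number from compound 2 to compound 3 (0.02 log units; within the scatter). Compound 3 is estimated at 1800 nM, with a range of 800 nM to 4000 nM.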

Compound 3, half-maximal inhibitory concentration: 1600 nM
For compound 3 the middle estimate is 1.1-fold (0.05 log units) above the measured one; the measured number falls inside the stated range.
By their numbers in this assay, from the lowest: compounds 1, 3 and 2 (each within the scatter of the next).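

In this assay ((tert-butyl)carbonyl)oxy, at 7 heavy atoms against 1 for chloro, gives a 1.1-fold lower number from compound 2 to compound 3 (0.03 log units; within the scatter) and so shows that this aromatic carbon carries a much larger group with no change beyond the scatter. (Tert-butyl)carbonyl in place of ethyl on the oxygen gives a 1.1-fold higher number from compound 1 to compound 3 (0.03 log units; within the scatter) and likewise leaves the number within the scatter. No supporting data are available to account for this flat response.

As far as these compounds go, whether an amine or a carboxylic acid on this aromatic carbon would move the number beyond the scatter remains open.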